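Swapping a chloro for a methoxy on the phenyl ring

The compounds below may be only part of what the source reports. "The series", "measured", "known", "first", "only" and "open" are said of these compounds alone.

Of the compounds shown here, three sharing one core have been measured in a physicochemical assay for solubility, read by HPLC, in phosphate buffer, with a stated time of 16 h, at pH 6.8; on this read-out lower numbers stand for lower solubility and higher numbers for higher solubility. Compound 1 `C[C@H](NC(=O)Cn1nnc2ccccc2c1=O)c1ccc(Cl)cc1` gives 1900 nM. Compound 2 `Cc1ccc([C@H](C)NC(=O)Cn2nnc3ccccc3c2=O)cc1` gives 12000 nM, and compound 3 `C[C@@H](NC(=O)Cn1nnc2ccccc2c1=O)c1ccccc1` gives 1200 nM. Among these three numbers compound 1 stands second highest: compound 3 sits within the scatter of it, so the two cannot be told apart, while compound 2 lies clearly higher, the one step that is beyond the scatter.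

Compound 4 `COc1ccc([C@H](C)NC(=O)Cn2nnc3ccccc3c2=O)cc1` is not yet measured. It differs from compound 1 in one place: methoxy in place of chloro on an aromatic carbon.

Among the compounds with values here, the only measured step that bears on this is the one in which a methyl replaced the same chloro, a 6.3-fold higher number from compound 1 to compound 2 (0.80 log units; beyond the scatter), a modest rise. A methoxy entering at that same aromatic carbon is a change of a similar kind, so a rise of comparable size in this assay is expected, though its exact extent is uncertain with a single comparison to lean on. The expected step is a 3.9-fold higher number from compound 1 to compound 4 (0.60 log units; beyond the scatter). Compound 4 is therefore estimated at 7500 nM, with a likely range from 2500 nM to 20000 nM.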

Compound 4, solubility: 15000 nM
Beside the measured number, compound 4's estimate is 2.0-fold (0.30 log units) below it; the range from low to high includes it.
By their numbers in this assay, from the lowest: compounds 3 and 1 (each within the scatter of the next); then compounds 2 and 4 (each within the scatter of the next).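

In this assay, the change from 4-chlorophenyl to 4-methoxyphenyl gives a 7.9-fold higher number from compound 1 to compound 4 (0.90 log units; beyond the scatter) on the read-out, so this is now the second replacement of the chloro at this aromatic carbon to end clearly higher, after the methyl with a 6.3-fold higher number from compound 1 to compound 2 (0.80 log units; beyond the scatter) in the same assay. The two replacements cannot be told apart, with a 1.3-fold higher number from compound 2 to compound 4 (0.10 log units; within the scatter) on the same scale, so the extra oxygen of the methoxy brings no visible difference from the methyl here. No supporting measurement is available to explain either rise.

Going by these compounds, whether an amine, a carboxylic acid or a longer chain such as butoxy at this carbon would give a similar number remains open. It is also unknown whether a methoxy on another carbon of the ring would behave the same way.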